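The source may report more compounds than this note shows. Statements on the series, on what has been measured and on what is new or still open speak of the compounds shown alone.

Among the compounds with values here, compound 2 `C=C(C)C(=O)N(Cc1ccc(OC)c(O)c1)c1cc(OC)c(OC)c(OC)c1` gives 390 nM in a functional assay on MGC-803 cells (Homo sapiens) for inhibition, read by MTT assay, with a stated time of 48 h (a higher number here means a weaker inhibitor, a lower number a stronger inhibitor), the higher of the two numbers so far. Within the data shown here, compound 1 `COc1ccc(CN(C(=O)C(C)Br)c2cc(OC)c(OC)c(OC)c2)cc1O` gives 120 nM in this assay, and the one measured step is a 3.3-fold higher number from compound 1 to compound 2 (0.51 log units; beyond the scatter). Compound 3 `CCC/C=C/C(=O)N(Cc1ccc(OC)c(O)c1)c1cc(OC)c(OC)c(OC)c1` differs from compound 2 by pent-1-en-1-yl in place of 1-methylethenyl on a carbonyl carbon. The measured step concerns the same carbonyl substituent but a different group, so it bears only loosely on this change, and its modest size suggests a small move at most. Compound 3 is therefore expected to stay close to compound 2, a 1.3-fold higher number from compound 2 to compound 3 (0.11 log units; within the scatter), with an estimated 500 nM and a range of 200 nM to 1300 nM.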

Compound 3, half-maximal inhibitory concentration: 70 nM
Compound 3: the middle estimate sits 7.1-fold (0.85 log units) above what was measured, and the stated range ends above it.
By their numbers in this assay, from the lowest: compounds 3 and 1 (each within the scatter of the next); then compound 2.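

On this carbonyl carbon, the larger pent-1-en-1-yl group does not cost activity in this assay: replacing 1-methylethenyl with it gives the change seen (a 5.6-fold lower number from compound 2 to compound 3 (0.75 log units; beyond the scatter)), so the earlier loss with 1-methylethenyl is not a general feature of alkenyl groups here. Pent-1-en-1-yl and 1-bromoethyl cannot be told apart (a 1.7-fold lower number from compound 1 to compound 3 (0.23 log units; within the scatter)), so two quite different groups give similar numbers at this place. Nothing available explains the gain. Going by these compounds, it remains open whether the double bond or the chain length matters, which a saturated pentyl group would address, and how a longer chain or an amine would behave here.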